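The source may report more compounds than this note shows. Statements on the series, on what has been measured and on what is new or still open speak of the compounds shown alone.

Compound 2 `COc1cc(Cl)cc(-c2nn(-c3cccc(NC(=O)Nc4ccc(Cl)c(C(F)(F)F)c4)c3)cc2-c2ccncc2)c1` holds the lower of the two numbers measured in a functional assay on A549 cells (Homo sapiens) for inhibition, read by sulforhodamine B assay, with a stated time of 48 h; a lower number here means a stronger inhibitor, a higher number a weaker inhibitor: compound 2 gives 680 nM, while compound 1 `O=C(Nc1cccc(-n2cc(-c3ccncc3)c(-c3cc(O)cc(Cl)c3)n2)c1)Nc1ccc(Cl)c(Cl)c1` gives 1960 nM, a gap beyond the scatter. Compound 3 `COc1cc(Cl)cc(-c2nn(-c3cccc(NC(=O)Nc4ccc(Cl)c(Cl)c4)c3)cc2-c2ccncc2)c1` keeps everything of compound 2 except one exchange: chloro in place of trifluoromethyl on an aromatic carbon. Among the measured compounds shown here, no measured pair shows this exchange, so nothing in hand sets its size. A modest step from compound 2 to compound 3, or none beyond the scatter, is expected, leaning slightly weaker. Compound 3 is therefore estimated at 950 nM in this assay, within 400 nM to 2200 nM. This amounts to an expected step of a 1.4-fold higher number from compound 2 to compound 3 (0.15 log units; within the scatter).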

Compound 3, half-maximal inhibitory concentration: 1480 nM
Compound 3: the middle estimate sits 1.6-fold (0.19 log units) below what was measured; measured number inside the range.
By their numbers in this assay, from the lowest: compound 2; then compounds 3 and 1 (each within the scatter of the next).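

In this assay, chloro in place of trifluoromethyl on this aromatic carbon now has a measured size, a 2.2-fold higher number from compound 2 to compound 3 (0.34 log units; beyond the scatter), so this position responds to the group it carries. Compound 3 also connects with compound 1: methyl in place of hydrogen on the oxygen gives a 1.3-fold lower number from compound 1 to compound 3 (0.12 log units; within the scatter), so that change shows no effect that can be told from the scatter. Nothing at hand explains the step at the chloro position.

Going by these compounds, whether bromo, methyl or a nitrile at this position would give a number nearer that of compound 2 or compound 3 remains open. So does the effect of an ethyl or longer chain on the oxygen.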